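Methoxy for Fluoro on the Benzyl Arm

This account rests on a few compounds, and the source may have more. Where it says the series, first, only, none or still open, it means among the compounds named here.

Among three compounds sharing one core, compound 3 `O=C(O)c1ccccc1-c1ccc(CCc2ncc(Cc3cccc(F)c3)[nH]2)cc1` gives the lowest number in an in vitro functional assay on cells for agonist activity at Bombesin receptor subtype-3 (Homo sapiens), read by luminescence and calcium flux (a higher number here means that more compound is needed for the effect, a lower number that less compound is needed), at 159 nM. Compound 1 `O=C(O)c1ccccc1-c1ccc(CCc2ncc(CCC3CCCCC3)[nH]2)cc1` gives 642 nM in this assay, and compound 2 `N#Cc1ccccc1Cc1cnc(CCc2ccc(-c3ccccc3C(=O)O)cc2)[nH]1` gives 5480 nM. Every step between the three lies beyond the scatter: a 4.0-fold lower number from compound 1 to compound 3 (0.61 log units; beyond the scatter), a 34-fold lower number from compound 2 to compound 3 (1.54 log units; beyond the scatter), and an 8.5-fold higher number from compound 1 to compound 2 (0.93 log units; beyond the scatter). Compound 3 therefore stands lowest of the three, with compound 1 as its nearest neighbour and compound 2 furthest away.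

Compound 4 `COc1cccc(Cc2cnc(CCc3ccc(-c4ccccc4C(=O)O)cc3)[nH]2)c1` is not yet measured. Its difference from compound 3 is methoxy in place of fluoro on an aromatic carbon. Within the data shown here, none of the measured steps swaps one substituent for another on the same aromatic ring; each replaces the whole group on the saturated chain carbon, and the step from compound 2 to compound 3 shows how widely such a swap can move the number. The change here is smaller in kind, a single substituent exchanged on the ring that compound 3 already carries. The step expected for compound 4 is therefore a 1.6-fold higher number from compound 3 to compound 4 (0.20 log units; within the scatter), small and uncertain in direction. Compound 4 is estimated at 250 nM in this assay, with a range from 80 nM to 800 nM.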

Compound 4, half-maximal effective concentration: 4120 nM
Compound 4: middle estimate off by 16-fold (1.22 log units), on the low side, and the stated range ends below it.
By their numbers in this assay, from the lowest: compound 3; then compound 1; then compounds 4 and 2 (each within the scatter of the next).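

The ring substituent alone proves decisive at this place: a 26-fold higher number from compound 3 to compound 4 (1.41 log units; beyond the scatter) in this assay comes from exchanging fluoro for methoxy, whereas the earlier large step, a 34-fold lower number from compound 2 to compound 3 (1.54 log units; beyond the scatter), replaced the whole group on the saturated chain carbon. The 3-fluorobenzyl group thus owes its standing to the fluoro substituent and not to the benzyl arm as such, for with methoxy on the same ring the number shows a 1.3-fold lower number from compound 2 to compound 4 (0.12 log units; within the scatter) and so cannot be told apart from that of the 2-cyanophenyl compound. The exchange also carries the compound past the cyclohexylmethyl compound, which compound 3 had bettered, with a 6.4-fold higher number from compound 1 to compound 4 (0.81 log units; beyond the scatter). No measurement at hand accounts for the size of this step.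

Going by these compounds, whether a chlorine, a hydroxyl or an ethoxy group at this place would track fluoro or methoxy remains open, and two substituents on one ring define no trend. Also open, on these data alone, is whether methoxy on another carbon of this ring would carry the same penalty, or whether fluoro there would keep the low number of compound 3.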